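This account rests on a few compounds, and the source may have more. Where it says the series, first, only, none or still open, it means among the compounds named here.

Measured so far in an assay on isolated protein for binding affinity to leukotriene B4 receptor (Homo sapiens), tested at 0.1 uM; a lower number here means less inhibition, a higher number more inhibition at the concentration tested (going by the name of the read-out):
- compound 1, `CCc1cc(C(C)=O)c(O)cc1OCCCCC(C)(C)C#N`: compound 1 gives 5%
- compound 2, `CCc1cc(C(C)=O)c(O)cc1OCCCCCC(C)(C)C#N`: compound 2 gives 17%
- compound 3, `CCc1cc(C(C)=O)c(O)cc1OCCCC(C)(C)C(=O)O`: compound 3 gives 12%

Compound 1 sits at the bottom of the three numbers: the step of a number 12 percentage points higher from compound 1 to compound 2 (beyond the scatter) is beyond the scatter, while compound 3 lies within the scatter of compound 1, the step being a number 7 percentage points higher from compound 1 to compound 3 (within the scatter). Compound 2 and compound 3 are also within the scatter of each other, a number 5 percentage points lower from compound 2 to compound 3 (within the scatter).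

The next compound is compound 4, `CCc1cc(C(C)=O)c(O)cc1OCCCC(C)(C)c1nnn[nH]1`. It differs from compound 1 as follows: 1-(1H-tetrazol-5-yl)-1-methylethyl in place of 2-cyano-2-methylpropyl on a saturated chain carbon, three bonds along the chain from an oxygen on an aromatic ring

Among the measured compounds shown here, the step that bears most directly on this is the one from compound 1 to compound 3, which exchanges the same group at the same place, three bonds along the chain from an oxygen on an aromatic ring, for 1-carboxy-1-methylethyl, a group that likewise brings a hydrogen-bond donor; that step, a number 7 percentage points higher from compound 1 to compound 3 (within the scatter), stayed within the scatter. For the measured compounds named here, the only step beyond the scatter in this assay, a number 12 percentage points higher from compound 1 to compound 2 (beyond the scatter), concerns a change of chain length and not the terminal group, so it offers little guidance here. A step of about a number 7 percentage points higher from compound 1 to compound 4 (within the scatter) is therefore expected for compound 4, which would stay inside the scatter. Compound 4 is estimated at 12% in this assay, in a range from 0% to 30%.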

Compound 4, a percentage reported as inhibition, at one concentration (the size of the read-out at that concentration, not a potency): 28%
The estimate for compound 4 lay 16 percentage points below the measured number, within the range that was stated.
By their numbers in this assay, from the lowest: compounds 1, 3 and 2 (each within the scatter of the next, the first and the last beyond it); then compound 4.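

At this position, three bonds along the chain from an oxygen on an aromatic ring, the terminal group now matters in this assay: 1-(1H-tetrazol-5-yl)-1-methylethyl in place of 2-cyano-2-methylpropyl gives a step of a number 23 percentage points higher from compound 1 to compound 4 (beyond the scatter), whereas 1-carboxy-1-methylethyl gave only a number 7 percentage points higher from compound 1 to compound 3 (within the scatter). The direct exchange of carboxy for 1H-tetrazol-5-yl gives a number 16 percentage points higher from compound 3 to compound 4 (beyond the scatter), so these two terminal groups do not behave alike here, and the tetrazole also clears the chain-extended nitrile, with a number 11 percentage points higher from compound 2 to compound 4 (beyond the scatter), which makes compound 4 the highest of the four, though still a modest reading at a single concentration. Nothing available explains why the tetrazole differs from the carboxy or nitrile groups.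

Still open, from the compounds shown here alone, is whether 1H-tetrazol-5-yl keeps or extends this gain on a longer chain, as the nitrile series might suggest, and whether the two methyl groups on the carbon bearing it are needed. Going by these compounds, it is equally open how an acyl sulfonamide or a primary amide would read in place of the tetrazole at this position in this assay.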